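The source may hold more compounds than are shown below. What is called first, only, known or untested is meant among the compounds shown, and "the series" means these compounds.

Among the compounds with values here, compound 2, `O=S(=O)(Nc1nccs1)c1ccc2c(c1)OCC[C@@H]2c1ccc(C(F)(F)F)cc1N1CCNCC1`, is one of three compounds measured in a physicochemical assay for solubility (a higher number here means a more soluble compound, a lower number a less soluble compound), and in this assay compound 2 gives 288000 nM. Compound 1, `Cn1nccc1-c1cc(C(F)(F)F)ccc1[C@H]1CCc2cc(S(=O)(=O)Nc3ncccn3)ccc21`, gives 316000 nM in this assay, a number that lies within the scatter of the value for compound 2. Compound 3, `Cn1nccc1-c1cc(C(F)(F)F)ccc1[C@H]1CCOc2cc(S(=O)(=O)Nc3cccc(F)n3)ccc21`, gives 27000 nM in this assay, which stands well beyond the scatter below compound 2. No two of these compounds differ in one place only, so no single step can be read from them. Compound 4, `CN1CCN(c2cc(C(F)(F)F)ccc2[C@H]2CCOc3cc(S(=O)(=O)Nc4nccs4)ccc32)CC1`, has not yet been measured. It differs from compound 2 by methyl in place of hydrogen on an amine nitrogen in a ring. The expected step from compound 2 to compound 4 is a 1.4-fold lower number from compound 2 to compound 4 (0.16 log units; within the scatter), a modest fall that may stay within the scatter. Compound 4 is estimated to give 200000 nM in this assay, with a likely range from 80000 nM to 400000 nM.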

Compound 4, solubility: 176000 nM
The estimate for compound 4 lay 1.1-fold (0.06 log units) above the measured number, and the stated range covers the measured number.
By their numbers in this assay, from the lowest: compound 3; then compounds 4, 2 and 1 (each within the scatter of the next).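

Within the data shown here, compound 4 gives the first step that can be read in this assay: methyl in place of hydrogen on the amine nitrogen in the ring (a 1.6-fold lower number from compound 2 to compound 4 (0.21 log units; within the scatter)). On this nitrogen, then, the hydrogen can give way to methyl with the two values remaining within the scatter of each other. No measurement shown explains this result.

As far as these compounds go, whether an acetyl group or a longer chain such as propyl on the same nitrogen would also stay within the scatter remains open. So does whether methyl would behave alike with another sulfonamide partner on the core.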